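The compounds below may be only part of what the source reports. "The series", "measured", "known", "first", "only" and "open" are said of these compounds alone.

Of the compounds shown here, two that share one core have been measured so far in a functional assay on NCI-H460 cells (Homo sapiens) for inhibition, read by MTT assay, with a stated time of 24 h, tested at 0.1 ug/mL; a lower number here means less inhibition of growth, a higher number more inhibition of growth at the concentration tested. Compound 1 `O=C(CCCCC(S)CCS)Nc1ccc(OC(F)(F)F)cc1` gives 17.3%, while compound 2 `O=C(CCCCC(S)CCS)Nc1ccc([N+](=O)[O-])c(C(F)(F)F)c1` gives 3.2%. Compound 2 therefore holds the lower of the two numbers, and the gap between them lies beyond the usual scatter.

Compound 3 `O=C(CCCCC(S)CCS)Nc1ccc([N+](=O)[O-])cc1` has not yet been measured and departs from compound 2 in one place: hydrogen in place of trifluoromethyl on an aromatic carbon. In words, hydrogen stands in place of trifluoromethyl on an aromatic carbon. Within the data shown here, no measured pair in this small set shows a change of this kind, so the data offer no direct guide to it.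

A small rise in this assay is expected because compound 2 sits at 3.2%, which leaves little room for a fall. The expected change is a number 6.8 percentage points higher from compound 2 to compound 3 (within the scatter), most likely within the scatter, although a larger rise cannot be ruled out. For compound 3 the estimated value is 10%, with an expected range from 0% to 25%.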

Compound 3, percent growth inhibition at one concentration: 5.69%
Compound 3: the middle estimate sits 4.3 percentage points above what was measured; the range from low to high includes it.
By their numbers in this assay, from the lowest: compounds 2 and 3 (each within the scatter of the next); then compound 1.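

In this assay, placing hydrogen instead of trifluoromethyl on the aromatic carbon ortho to a nitro group gives a number 2.5 percentage points higher from compound 2 to compound 3 (within the scatter), so at this one concentration the data do not separate these two groups at this position. The change of nitro in place of trifluoromethoxy on an aromatic carbon gives a number 11.6 percentage points lower from compound 1 to compound 3 (beyond the scatter), a modest step beyond the scatter, and among these compounds it is the only single-place change that moves the number by more than the scatter. Nothing at hand gives a reason for either step.

From the compounds shown here alone, whether a different group on that aromatic carbon, such as an amine, a methyl group or a chlorine atom, would move the number beyond the scatter remains open, as does whether compound 2 and compound 3 stay this close at other concentrations. Going by these compounds, it is also open how the number would respond if the nitro group of compound 3 gave way to a nitrile or a carboxylic acid, or if the chain of the shared core were longer.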